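A few compounds are considered here, and "the series" means these few. Any claim that something is new, unique, unknown or untested is made for them only; others in the source may bear on it.

Compound 1, with the structure `COc1ccc(-c2c[nH]c(=O)n2-c2cc(OC)c(OC)c(OC)c2)cc1OC`, is the starting point of this set. In a functional assay on PC-3 cells (Homo sapiens) for cytotoxicity, read by MTT assay, with a stated time of 48 h (a higher number here means a weaker inhibitor, a lower number a stronger inhibitor), compound 1 gives > 50000 nM, which is a limit of the assay rather than a number. Compound 2, with the structure `COc1ccc(-c2c[nH]c(=O)n2-c2cc(OC)c(OC)c(OC)c2)cc1N`, differs from compound 1 by the change (amino in place of methoxy on an aromatic carbon). In this assay compound 2 gives 49800 nM. The step of a number no higher from compound 1 to compound 2 (the limit leaves the size open) cannot be sized because the limit of > 50000 nM in this assay, at which 2 of the 3 values shown sit, caps the first value. Compound 3, with the structure `COc1ccc(-c2cn(C(=O)Nc3cc(OC)c(OC)c(OC)c3)c(=O)n2-c2cc(OC)c(OC)c(OC)c2)cc1OC`, carries a core that differs from that of compound 1, and the difference between the two cores is not broken down here. In this assay compound 3 gives > 50000 nM, again a limit of the assay. Compound 4, with the structure `COc1ccc(-c2cn(C(=O)Nc3cc(OC)c(OC)c(OC)c3)c(=O)n2-c2cc(OC)c(OC)c(OC)c2)cc1N`, has not yet been measured; it differs from compound 3 by amino in place of methoxy on an aromatic carbon, the same change as between compound 1 and compound 2. Since the earlier step left its size open, the step from compound 3 to compound 4 is expected to be a number no higher from compound 3 to compound 4 (the limit leaves the size open). Compound 4 is therefore estimated to give 50000 nM in this assay, most likely again only as a limit.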

Compound 4, half-maximal inhibitory concentration: 10000 nM
Compound 4: the middle estimate sits 5.0-fold (0.70 log units) above what was measured; measured number outside the range, below it.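

On the core of compound 3, amino in place of methoxy, which turns 3,4-dimethoxyphenyl into 3-amino-4-methoxyphenyl, gives an at least 5.0-fold lower number from compound 3 to compound 4 (0.69 log units; beyond the scatter) in this assay. The same change on the core of compound 1 gives a step whose size cannot be read, so the two cores can be set side by side in direction only: the same change on two cores in this assay, a number no higher (the limit leaves the size open) from compound 1 to compound 2 and an at least 5.0-fold lower number (0.69 log units; beyond the scatter) from compound 3 to compound 4; the limit leaves it open whether they differ. The series thus shows a change that raised the number on neither core and lowered it clearly on one, but it does not show that the size of the effect carries from one core to the other, or that the cores truly differ, since the values involved rest on a limit of the assay: the limit of > 50000 nM in this assay, at which 2 of the 4 values shown sit.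

The compounds shown leave open how a hydroxyl, a dimethylamino or an acetamide group in the place of the amino would fare in this assay. They also leave open whether the amino change would hold on any third core.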